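Compound 4: replacing an aryl group at the assay limit

The compounds below may be only part of what the source reports. "The series", "measured", "known", "first", "only" and "open" are said of these compounds alone.

Measured in an ADME assay on PA-1 cells (Homo sapiens) for cytotoxicity, read by MTT assay, with a stated time of 72 h; on this read-out lower numbers stand for stronger inhibition and higher numbers for weaker inhibition:
compound 1 `COc1cc(C2=C(c3cc(C)c(OC)c(C)c3)C(O)CC2=O)cc(OC)c1OC`: > 100 ug/mL (a limit)
compound 2 `COc1cc(C2=C(c3cc(C)c(OC)c(C)c3)C(OC(C)=O)CC2=O)cc(OC)c1OC`: > 100 ug/mL (a limit)
compound 3 `COc1cc(C2=C(c3ccc(SC)cc3)CC(O[SiH2]C(C)(C)C)C2=O)cc(OC)c1OC`: < 1 ug/mL (a limit)

Compound 2 gives no number and stands at the limit of > 100 ug/mL in this assay, at which 2 of the 3 values shown sit. Compound 4 `COc1ccc(C2=C(c3cc(OC)c(OC)c(OC)c3)C(=O)CC2OC(C)=O)cc1NC=O` differs from it by 3-(formylamino)-4-methoxyphenyl in place of 4-methoxy-3,5-dimethylphenyl on a double-bonded ring carbon. Among the measured compounds shown here, the only measured step is a step that the two limits leave unreadable from compound 1 to compound 2; it concerns acetyl in place of hydrogen on an oxygen on a saturated carbon and gives no size to carry over. Compound 3 gives only the limit < 1 ug/mL and differs from compound 2 in several places, so it offers a loose hint of direction and no size. The expected change in this assay is an at least 2.5-fold lower number from compound 2 to compound 4 (0.39 log units; beyond the scatter), toward stronger inhibition, with its size poorly defined. For compound 4 the estimate is 40 ug/mL, with an expected range from 5 ug/mL to 120 ug/mL.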

Compound 4, half-maximal inhibitory concentration: 5 ug/mL
The estimate for compound 4 lay 8.0-fold (0.90 log units) above the measured number, within the range that was stated.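

In this assay, the double-bonded ring carbon proves sensitive to the aryl group it carries: 3-(formylamino)-4-methoxyphenyl in place of 4-methoxy-3,5-dimethylphenyl gives an at least 20-fold lower number from compound 2 to compound 4 (1.30 log units; beyond the scatter). Compound 2 stands only at a limit, so this step has a floor and no exact size, and the step from compound 1 to compound 2 cannot be read. Compound 4 is the only compound shown with a measured number rather than a limit.

The formylamino group and the loss of the two methyl groups change together, so neither can be credited separately. Going by these compounds, whether a free amine or an acetylamino group on that ring would hold the step remains open.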